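The source may hold more compounds than are shown below. What is called first, only, known or untested is meant among the compounds shown, and "the series" means these compounds.

Compound 1 `Cc1ccc2nc(C(=O)Nc3c(F)cc(-c4cccc(F)c4)cc3F)c(C)c(O)c2c1` gives 0.98% in a functional assay on Hep 3B2 cells (Homo sapiens) for antiproliferative activity, read by MTT assay, with a stated time of 24 h, tested at 0.02 ug/mL; on this read-out higher numbers stand for a stronger effect at the one concentration tested and lower numbers for a weaker effect. Compound 2 `CCc1ccc2nc(C(=O)Nc3c(F)cc(-c4cccc(F)c4)cc3F)c(C)c(O)c2c1` gives 2.05% in this assay. Compound 3 `Cc1ccc2nc(C(=O)Nc3c(F)cc(-c4cccc(F)c4)cc3F)c(C)c(C(=O)O)c2c1` gives 1.05% in this assay.

Among these three numbers compound 3 stands second highest. Its nearest neighbour is compound 1, and the step of a number 0.1 percentage points higher from compound 1 to compound 3 (within the scatter) is within the scatter; the furthest is compound 2, whose value differs from that of compound 3 by an amount that the two values show to be within the scatter as well. The three measured compounds therefore sit on one level in this assay.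

Compound 4 `CCc1ccc2nc(C(=O)Nc3c(F)cc(-c4cccc(F)c4)cc3F)c(C)c(C(=O)O)c2c1` differs from compound 3 by methyl in place of hydrogen on a saturated chain carbon bound to an aromatic carbon. For the measured compounds named here, one measured step bears on this change: the same replacement on the hydroxy compounds, a number 1.1 percentage points higher from compound 1 to compound 2 (within the scatter), which was within the scatter. On that basis the step from compound 3 to compound 4 is expected to be no larger than the scatter, and compound 4 is estimated at 2.1%, with a range from -5% to 10%, so that the expected step of a number 1.1 percentage points higher from compound 3 to compound 4 (within the scatter) stays within the scatter.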

Compound 4, a percentage reported as inhibition, at one concentration (the size of the read-out at that concentration, not a potency): -0.05%
Compound 4: the middle estimate sits 2.2 percentage points above what was measured; the range from low to high includes it.
By their numbers in this assay, from the lowest: compounds 4, 1, 3 and 2 (each within the scatter of the next).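

With this result, the change from methyl to ethyl on a saturated chain carbon bound to an aromatic carbon has been read on both the hydroxy and the carboxy compounds in this assay, and the step of a number 1.1 percentage points lower from compound 3 to compound 4 (within the scatter) shows no effect of this change on the carboxy compounds either: the same change on two cores in this assay, a number 1.1 percentage points higher (within the scatter) from compound 1 to compound 2 and a number 1.1 percentage points lower (within the scatter) from compound 3 to compound 4, 2.2 percentage points apart, within the scatter of two such steps. Carboxy in place of hydroxy on an aromatic carbon, until now read only on the methyl compounds, has also been read on the ethyl compounds, and the step of a number 2.1 percentage points lower from compound 2 to compound 4 (within the scatter) again stays inside the scatter: the same change on two cores in this assay, a number 0.1 percentage points higher (within the scatter) from compound 1 to compound 3 and a number 2.1 percentage points lower (within the scatter) from compound 2 to compound 4, 2.2 percentage points apart, within the scatter of two such steps. All four compounds therefore sit on one level, and neither change moves the read-out beyond the scatter at the one concentration tested.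

The compounds shown leave open whether a longer chain such as propyl, or an amine in place of the hydroxy or carboxy group, would lift the read-out beyond the scatter in this assay. They also leave open whether these four compounds would separate from one another at a higher concentration.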